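This account rests on a few compounds, and the source may have more. Where it says the series, first, only, none or still open, it means among the compounds named here.

Measured in an ADME assay on L929 cells (Mus musculus) for cytotoxicity, read by resazurin assay, with a stated time of 72 h; on this read-out higher numbers stand for weaker inhibition and lower numbers for stronger inhibition:
compound 1 `O=C(/C=C/c1ccc2c(c1)B(O)OC2)c1ccccc1O`: > 10 ug/mL
compound 2 `COc1ccccc1C(=O)/C=C/c1ccc2c(c1)B(O)OC2`: 6.35 ug/mL
compound 3 `COCOc1ccccc1C(=O)/C=C/c1ccc2c(c1)B(O)OC2`: 9.02 ug/mL

Compound 1 gives > 10 ug/mL, which is a limit of the assay and not a number. Going by the values given here, only two of the three compounds therefore carry true numbers. Compound 2 stands at 6.35 ug/mL, and its nearest neighbour is compound 3, with a 1.4-fold higher number from compound 2 to compound 3 (0.15 log units; within the scatter).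

The compound still to be measured is compound 4 `COc1ccc(C(=O)/C=C/c2ccc3c(c2)B(O)OC3)c(OC)c1`. It differs from compound 2 by methoxy in place of hydrogen on an aromatic carbon, meta to a methoxy group and para to a large group.

Among the compounds with values here, no measured step makes this change, so the evidence is only indirect. The closest guides are the changes on the oxygen on the aromatic ring. Two of them, an at least 1.5-fold lower number from compound 1 to compound 2 (0.19 log units; that floor lies within the scatter) and an at least 1.1-fold lower number from compound 1 to compound 3 (0.04 log units; that floor lies within the scatter), are only floors, and both rest on (the limit of > 10 ug/mL in this assay, at which 1 of the 3 values shown sits). The third is the small step already given between the two true numbers. None of the three lies beyond the scatter, so no step beyond the scatter is expected in this assay. The expected step is a 1.0-fold higher number from compound 2 to compound 4 (0.01 log units; within the scatter). For compound 4 the estimated value is 6.5 ug/mL, with an expected range from 3 ug/mL to 12 ug/mL.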

Compound 4, half-maximal inhibitory concentration: 7.87 ug/mL
Compound 4: middle estimate off by 1.2-fold (0.08 log units), on the low side, and the stated range covers the measured number.
By their numbers in this assay, from the lowest: compounds 2, 4 and 3 (each within the scatter of the next). At a limit, above all of these: compound 1.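

Going by these compounds alone, until now, the only changes were to the group on the oxygen on the aromatic ring. Within the data shown here, this step is the first to change an aromatic carbon of that six-membered aromatic ring, and in this assay methoxy in place of hydrogen, meta to a methoxy group and para to a large group, gives a 1.2-fold higher number from compound 2 to compound 4 (0.09 log units; within the scatter). The position therefore accepts this methoxy group with no step beyond the scatter on this read-out, so a second methoxy group on the ring leaves the cytotoxicity number where a single one put it, as far as this one pair can show. Nothing given here offers a reason for the size of this step.

The compounds shown leave open whether a different group on this aromatic carbon, such as an amine, a carboxylic acid or a longer chain ending in an alcohol, would produce a step beyond the scatter. They also leave open how the same methoxy group would read on the other aromatic carbons of this ring.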